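This account rests on a few compounds, and the source may have more. Where it says the series, first, only, none or still open, it means among the compounds named here.

- compound 1 `Cc1ccc2[nH]c(-c3ccc(-c4ccc(-c5cccc(Cl)c5)cc4)cc3)nc2c1`: 2740 nM
- compound 2 `Oc1cccc2[nH]c(-c3ccc(-c4ccc(-c5ccc(C(F)(F)F)cc5)cc4)cc3)nc12`: 3200 nM

In a functional assay on HOP-62 cells (Homo sapiens) for inhibition, read by sulforhodamine B assay (on this read-out higher numbers stand for weaker inhibition of growth and lower numbers for stronger inhibition of growth), compound 2 gives 3200 nM, a value within the usual scatter of that of compound 1. Compound 3 `Cc1ccc2[nH]c(-c3ccc(-c4ccc(-c5ccc(C(F)(F)F)cc5)cc4)cc3)nc2c1` has 5-methyl-1H-benzimidazol-2-yl in place of 4-hydroxy-1H-benzimidazol-2-yl on an aromatic carbon. Among the measured compounds shown here, no measured pair isolates this swap, so the evidence is indirect. Compound 1 carries the same 5-methyl-1H-benzimidazol-2-yl group and gives 2740 nM, which suggests no large shift. The expected 1.1-fold lower number from compound 2 to compound 3 (0.03 log units; within the scatter) therefore stays within the scatter. For compound 3 the estimated value is 3000 nM, with an expected range of 1200 nM to 7500 nM.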

Compound 3, concentration for 50% growth inhibition: 24200 nM
Beside the measured number, compound 3's estimate is 8.1-fold (0.91 log units) below it; the whole stated range lies below it.
By their numbers in this assay, from the lowest: compounds 1 and 2 (each within the scatter of the next); then compound 3.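

In this assay, 5-methyl-1H-benzimidazol-2-yl in place of 4-hydroxy-1H-benzimidazol-2-yl gives a 7.6-fold higher number from compound 2 to compound 3 (0.88 log units; beyond the scatter), so this position is sensitive to the group it carries. The far end of the molecule matters as well: 4-(trifluoromethyl)phenyl in place of 3-chlorophenyl gives an 8.8-fold higher number from compound 1 to compound 3 (0.95 log units; beyond the scatter). The similar numbers of the two earlier compounds, which differ in two places, therefore gave no sign of either single-change step. Going by these compounds, what an amine or a carboxylic acid would do on the benzimidazole stays open. No available measurement gives a reason for either step.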